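A few compounds are considered here, and "the series" means these few. Any claim that something is new, unique, unknown or untested is made for them only; others in the source may bear on it.

In a functional assay on BGC-823 cells (Homo sapiens) for inhibition, read by MTT assay, with a stated time of 72 h (a lower number here means a stronger inhibitor, a higher number a weaker inhibitor), compound 1 (`Cc1cc(N2CC[C@@H](C)[C@@H](N(C)c3ncnc4[nH]ccc34)C2)n2nc(SCC3CC3)nc2n1`) gives 36500 nM. Compound 3 (`Cc1cc(N2CC[C@@H](C)[C@@H](N(C)c3ncnc4[nH]ccc34)C2)n2nc(SCCc3ccccc3)nc2n1`) gives 28000 nM, and these two values lie within the scatter of each other. Compound 2 (`C[C@@H]1CCN(c2cc(-c3ccccc3)nc3ncnn23)C[C@@H]1N(C)c1ncnc2[nH]ccc12`) gives > 100000 nM, which is a limit of the assay and not a number. For the measured compounds named here, compound 1 therefore stands level with compound 3, the only other numerical value.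

Compound 4 (`Cc1cc(N2CC[C@@H](C)[C@@H](N(C)c3ncnc4[nH]ccc34)C2)n2nc(SCc3ccc(F)c(Cl)c3)nc2n1`) has not yet been measured. The change from compound 1 is 3-chloro-4-fluorophenyl in place of cyclopropyl on a saturated chain carbon bound to a sulfur. Cut one bond further out, this reads cyclopropylmethyl to 3-chloro-4-fluorobenzyl.

Going by the values given here, one measured step bears on this, with benzyl in place of cyclopropyl at the same place: a 1.3-fold lower number from compound 1 to compound 3 (0.12 log units; within the scatter). That single step stays within the scatter. Among the compounds with values here, the fluorine and chlorine of the entering group have no measured counterpart, which widens the uncertainty. No shift beyond the scatter is therefore expected in this assay. The expected step is a 1.5-fold lower number from compound 1 to compound 4 (0.16 log units; within the scatter), an estimate that stays within the scatter. Compound 4 is expected at 25000 nM, with an estimated range of 8000 nM to 70000 nM.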

Compound 4, half-maximal inhibitory concentration: 98900 nM
Estimate against measurement, compound 4: 4.0-fold (0.60 log units) below; measured number above the stated range.
By their numbers in this assay, from the lowest: compounds 3 and 1 (each within the scatter of the next); then compound 4. At a limit, above all of these: compound 2.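

In this assay, the place on a saturated chain carbon bound to a sulfur can move the number beyond the scatter: 3-chloro-4-fluorophenyl in place of cyclopropyl gives a 2.7-fold higher number from compound 1 to compound 4 (0.43 log units; beyond the scatter). An aromatic ring here does not by itself set the number, since compound 1 and compound 3 stay within the scatter of each other, while the step to the halogenated ring is a 3.5-fold higher number from compound 3 to compound 4 (0.55 log units; beyond the scatter). Compound 2 carries a limit, and the number of compound 4 lies close to it, so any further rise in this direction may not be readable in this assay: the limit of > 100000 nM in this assay, at which 1 of the 4 values shown sits.

The step from compound 3 changes both the chain and the halogens, so the shift cannot be assigned to the chlorine, the fluorine or the chain length; a plain benzyl, a 3-chlorobenzyl or a 4-fluorobenzyl on the sulfur would separate these. Going by these compounds, how an amine or a carboxylic acid at the end of the chain would read in this assay also stays open.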